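A few compounds are considered here, and "the series" means these few. Any claim that something is new, unique, unknown or untested is made for them only; others in the source may bear on it.

The measured compounds are:
compound 1, `O=C(CN(c1ncnc2c1ncn2C1CCCCO1)C1CC1)N[C@@H](CO)C(=O)OCc1ccccc1`, 18.3%;
compound 2, `NC(=O)CC[C@H](NC(=O)CN(c1ncnc2c1ncn2C1CCCCO1)C1CC1)C(=O)OCc1ccccc1`, 10.7%;
compound 3, `O=C(CN(c1nc(Cl)nc2[nH]cnc12)C1CC1)N[C@@H](CCC(=O)OCc1ccccc1)C(=O)OCc1ccccc1`, 44.5%.

In a functional assay on the whole organism (Tail, strain ICR) with Mus musculus as the target, in the tail flick test, with a stated time of 150 min, at a dose of 25 umol/kg by the oral route (a higher number here means a stronger effect of the compound at the dose given, a lower number a weaker effect), compound 2 gives the smallest of the three numbers; compound 1 sits within the scatter of it, and only compound 3 lies beyond. Compound 4, `C[C@H](NC(=O)CN(c1ncnc2c1ncn2C1CCCCO1)C1CC1)C(=O)OCc1ccccc1`, is not yet measured; it differs from compound 2 by hydrogen in place of carbamoylmethyl on a saturated chain carbon, two bonds along the chain from an amide-type nitrogen and a carbonyl carbon. Among the measured compounds shown here, the one measured step at this place is a number 7.6 percentage points lower from compound 1 to compound 2 (within the scatter), which stayed within the scatter. Nothing measured shows a change at this place that moves the read-out beyond the scatter, so the expected step is a number 4.3 percentage points higher from compound 2 to compound 4 (within the scatter), no more than the scatter in either direction. Compound 4 is accordingly estimated at 15%, with a range from 5% to 30%.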

Compound 4, a percentage reported as activity, at one dose (the size of the read-out at that dose, not a potency): 6.01%
Beside the measured number, compound 4's estimate is 9 percentage points above it, within the range that was stated.
By their numbers in this assay, from the lowest: compounds 4, 2 and 1 (each within the scatter of the next, the first and the last beyond it); then compound 3.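

In this assay the change to hydrogen gives a number 4.7 percentage points lower from compound 2 to compound 4 (within the scatter) and so removes the carbamoylmethyl without a clear loss, yet the same hydrogen gives a number 12.3 percentage points lower from compound 1 to compound 4 (beyond the scatter) when it replaces hydroxy. Among the compounds shown here, that is the first step at this place to pass the scatter, though only modestly, and it separates the hydroxy compound from the bare chain. No measured evidence bears on why this step arises. Left open is whether an amine, a carboxylic acid or a longer chain here would move the read-out further, and whether the step holds on the core of compound 3.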